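A few compounds are considered here, and "the series" means these few. Any claim that something is new, unique, unknown or untested is made for them only; others in the source may bear on it.

Measured in a functional assay on HCT-116 cells (Homo sapiens) for inhibition, read by colorimetric assay, with a stated time of 3 days; on this read-out lower numbers stand for stronger inhibition and higher numbers for weaker inhibition:
compound 1, `O=C(CCCCCCNC(=O)C(O)(O)C(F)(F)F)Nc1nccs1`, gives 10800 nM
compound 2, `O=C(CCCCCCNC(=O)C(O)(O)C(F)(F)F)Nc1cccc(Br)c1`, gives 3060 nM
compound 3, `O=C(CCCCCCNC(=O)C(O)(O)C(F)(F)F)Nc1ccc(Br)cc1`, gives 3130 nM

Compound 1 stands at the highest of the three numbers; both other compounds sit beyond the scatter below it, so it is the weakest inhibitor of the set. Compound 4, `O=C(CCCCCCNC(=O)C(O)(O)C(F)(F)F)Nc1ncc(-c2ccc(O)cc2)s1`, differs from compound 1 in one place: 4-hydroxyphenyl in place of hydrogen on an aromatic carbon. Among the compounds with values here, no measured step makes exactly this kind of change, since none of the measured pairs adds a group onto a ring; the evidence is indirect. The steps of a 3.5-fold lower number from compound 1 to compound 2 (0.55 log units; beyond the scatter) and a 3.5-fold lower number from compound 1 to compound 3 (0.54 log units; beyond the scatter) show that exchanging the five-membered ring of compound 1 for a bromophenyl ring lowers the number modestly, and the step of a 1.0-fold higher number from compound 2 to compound 3 (0.01 log units; within the scatter) shows that moving the bromine around that ring makes no difference beyond the scatter. In both informative steps, the compound that carries a six-membered aromatic ring of carbon only gives the lower number. Compound 4 keeps the five-membered ring and adds such a six-membered ring to it, so a modest lowering is expected, though with real uncertainty. Compound 4 is therefore expected to show a 2.4-fold lower number from compound 1 to compound 4 (0.38 log units; beyond the scatter). Compound 4 is estimated at 4500 nM, with a range from 1500 nM to 13000 nM.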

Compound 4, half-maximal inhibitory concentration: 1020 nM
Compound 4: middle estimate off by 4.4-fold (0.64 log units), on the high side; measured number below the stated range.
By their numbers in this assay, from the lowest: compound 4; then compounds 2 and 3 (each within the scatter of the next); then compound 1.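

In this assay, placing 4-hydroxyphenyl in place of hydrogen on the aromatic carbon next to the ring sulfur gives an 11-fold lower number from compound 1 to compound 4 (1.02 log units; beyond the scatter), a large step. Within the data shown here, the earlier compounds tested only an exchange of the whole ring on the amide-type nitrogen, as in a 3.5-fold lower number from compound 1 to compound 2 (0.55 log units; beyond the scatter), so this is the first sign that the five-membered ring can stay and that adding a sizeable group at this carbon can lower the number much further. Nothing given here accounts for the size of this step, so the result stands as an observation without an explanation.

The compounds shown leave open whether the six-membered aromatic ring alone carries this step or the hydroxy group on it has a share, a question that a plain phenyl or a 4-methoxyphenyl at the same carbon would address. Also open, as far as these compounds go, is whether a much smaller group at this carbon, such as methyl or bromine, would lower the number at all, or whether an amine in place of the hydroxy group would keep the step.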